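Swapping chlorines for a methyl: an expected cytotoxicity shift

The source may hold more compounds than are shown below. What is called first, only, known or untested is meant among the compounds shown, and "the series" means these compounds.

Measured compounds:
- compound 1, `N#Cc1ccc(Nc2nc(Oc3ccc(Cl)cc3Cl)c3ccccc3n2)cc1`: 32000 nM
- compound 2, `N#Cc1ccc(Nc2nc(Oc3ccc(Cl)cc3)c3ccccc3n2)cc1`: 198000 nM
- compound 3, `N#Cc1ccc(Nc2nc(Oc3c(Cl)cc(Cl)cc3Cl)c3ccccc3n2)cc1`: 56000 nM

All three share one core and were tested in an ADME assay on MT4 cells (Homo sapiens) for cytotoxicity, read by MTT assay, with a stated time of 4 days; a higher number here means that more compound is tolerated, a lower number that less compound is tolerated. In this assay compound 3 gives 56000 nM, the second highest of the three numbers. The step of a 1.8-fold higher number from compound 1 to compound 3 (0.24 log units; within the scatter) lies within the scatter, whereas a 3.5-fold lower number from compound 2 to compound 3 (0.55 log units; beyond the scatter) lies beyond it, so compound 3 is tolerated less well than compound 2 but is not distinguishable from compound 1.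

Compound 4, `Cc1ccc(Oc2nc(Nc3ccc(C#N)cc3)nc3ccccc23)cc1`, differs from compound 3 in one place: 4-methylphenyl in place of 2,4,6-trichlorophenyl on an oxygen on an aromatic ring. Going by the values given here, two measured steps bear on this. Removing one chloro gave a 6.2-fold higher number from compound 1 to compound 2 (0.79 log units; beyond the scatter), and adding two chloros gave a 3.5-fold lower number from compound 2 to compound 3 (0.55 log units; beyond the scatter). Compound 4 removes all three chlorines at once, which points toward a higher number, roughly back at the level of compound 2; the methyl has no precedent among these compounds, so its effect is unknown.

Compound 4 is therefore expected to show a step of a 2.7-fold higher number from compound 3 to compound 4 (0.43 log units; beyond the scatter) upward in this assay, beyond the scatter. The estimate for compound 4 is 150000 nM, within a range from 50000 nM to 400000 nM.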

Compound 4, half-maximal cytotoxic concentration: 87000 nM
Compound 4: the middle estimate sits 1.7-fold (0.24 log units) above what was measured; low and high end bracket the measured number.
By their numbers in this assay, from the lowest: compounds 1, 3 and 4 (each within the scatter of the next, the first and the last beyond it); then compound 2.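

Going by these compounds alone, replacing the chloro of compound 2 with a methyl gave a 2.3-fold lower number from compound 2 to compound 4 (0.36 log units; beyond the scatter) in this assay, so having no chlorine on this ring does not by itself give the highest number, and the single 4-chlorophenyl of compound 2 remains the best tolerated of the four. The 4-methylphenyl group gave a 1.6-fold higher number from compound 3 to compound 4 (0.19 log units; within the scatter) against the 2,4,6-trichlorophenyl group, yet a 2.7-fold higher number from compound 1 to compound 4 (0.43 log units; beyond the scatter) against the 2,4-dichlorophenyl group, so it separates from only one of the two more chlorinated rings. No measurement here explains these differences.

The compounds shown leave open whether the methyl itself lowers the number or whether any group other than chloro would do the same. An amine or a carboxylic acid on this ring, or a longer chain in place of the methyl, could move the number in either direction.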